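The source may report more compounds than this note shows. Statements on the series, on what has been measured and on what is new or still open speak of the compounds shown alone.

Compound 1 `COC(=O)C1=C(N)Oc2c(OC)cc(Br)cc2C1CC(=O)c1cccc(OC)c1` gives 94.9% in a functional assay on MCF7 cells (Homo sapiens) for antiproliferative activity, read by sulforhodamine B assay, with a stated time of 72 h, tested at 30 uM; on this read-out lower numbers stand for a stronger effect and higher numbers for a weaker effect at the one concentration tested. Compound 2 `COC(=O)C1=C(N)Oc2c(OC)cc(Br)cc2C1CC(=O)c1ccc(Br)cc1` gives 31.9% in this assay. Compound 3 `COc1cccc(C(=O)CC2C(C#N)=C(N)Oc3c(OC)cc(Br)cc32)c1` gives 33.9% in this assay.

Two single changes connect these three compounds. The first, (4-bromophenyl in place of 3-methoxyphenyl on a carbonyl carbon), makes the step of a number 63 percentage points lower from compound 1 to compound 2 (beyond the scatter). The second concerns the core itself: cyano in place of methoxycarbonyl on a double-bonded ring carbon, with the step of a number 61 percentage points lower from compound 1 to compound 3 (beyond the scatter). Compound 2 and compound 3 thus end up close to each other, and their two values are within the scatter of one another, so no order between them can be read.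

Compound 4 `COc1cc(Br)cc2c1OC(N)=C(C#N)C2CC(=O)c1ccc(Br)cc1` is the compound not yet measured. Within the data shown here, it differs from compound 3 by 4-bromophenyl in place of 3-methoxyphenyl on a carbonyl carbon, and this is the same change as the one from compound 1 to compound 2, made at the same place. On the core of compound 1 that change was large. On the core of compound 3, however, the starting point is already low, since compound 3 gives 33.9%, which leaves far less room on this read-out than compound 1 had. Compound 4 is therefore expected to move downward by a smaller step, a number 18.9 percentage points lower from compound 3 to compound 4 (beyond the scatter), rather than by a step of the earlier size. Compound 4 is estimated at 15%, with a range from 2% to 35%, resting on the value of compound 3 and on the direction of the step from compound 1 to compound 2.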

Compound 4, a percentage reported as activity, at one concentration (the size of the read-out at that concentration, not a potency): 33.1%
The estimate for compound 4 lay 18.1 percentage points below the measured number; low and high end bracket the measured number.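

In this assay, putting 4-bromophenyl in place of 3-methoxyphenyl on a carbonyl carbon gives a number 0.8 percentage points lower from compound 3 to compound 4 (within the scatter), so the large effect seen on the core of compound 1 does not carry over to the core of compound 3: the same change on two cores in this assay, a number 63 percentage points lower (beyond the scatter) from compound 1 to compound 2 and a number 0.8 percentage points lower (within the scatter) from compound 3 to compound 4, 62.2 percentage points apart, beyond the scatter of two such steps. Read along the other edge of the same set of four, cyano in place of methoxycarbonyl on a double-bonded ring carbon gives a number 1.2 percentage points higher from compound 2 to compound 4 (within the scatter), and this change does not carry over either: the same change on two cores in this assay, a number 61 percentage points lower (beyond the scatter) from compound 1 to compound 3 and a number 1.2 percentage points higher (within the scatter) from compound 2 to compound 4, 62.2 percentage points apart, beyond the scatter of two such steps. The two changes therefore do not add up in this series, as either one alone brings compound 1 to the level shared by compound 2, compound 3 and compound 4, but these four compounds at a single concentration do not show why, nor whether that shared level is a true plateau of the effect or holds only for these groups.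

The compounds shown leave open whether another group on the carbonyl carbon, such as an unsubstituted phenyl or a 4-chlorophenyl, would also differ between the two cores. They also leave open whether a carboxylic acid or a primary amide in place of methoxycarbonyl would match cyano in this respect.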